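The source may report more compounds than this note shows. Statements on the series, on what has been measured and on what is new or still open speak of the compounds shown alone.

Compound 3, `CC/N=C(\S)OC[C@H]1OC(n2cnc3c(NC4CCOC4)nc(Cl)nc32)[C@H](O)[C@@H]1O`, gives 55 nM in an assay on DDT1 cells (Cricetulus griseus) for binding affinity to adenosine receptor A1 (Homo sapiens), read by radioligand binding (a lower number here means a stronger inhibitor, a higher number a weaker inhibitor), the lowest of the three measured numbers. Compound 2, `C/N=C(\S)OC[C@H]1OC(n2cnc3c(NC4CCOC4)nc(Cl)nc32)[C@H](O)[C@@H]1O`, gives 71 nM, and compound 1, `CNC(=O)OC[C@H]1OC(n2cnc3c(NC4CCOC4)nc(Cl)nc32)[C@H](O)[C@@H]1O`, gives 96 nM. Both steps to compound 3 are small: a 1.7-fold lower number from compound 1 to compound 3 (0.24 log units; within the scatter) and a 1.3-fold lower number from compound 2 to compound 3 (0.11 log units; within the scatter), each within the scatter. Compound 4 is `O=C(NC1CCCC1)OC[C@H]1OC(n2cnc3c(NC4CCOC4)nc(Cl)nc32)[C@H](O)[C@@H]1O`; the change is a group of 8 heavy atoms (6 carbon, 1 nitrogen, 1 oxygen; one five-membered non-aromatic ring of carbon only) in place of a group of 5 heavy atoms (3 carbon, 1 nitrogen, 1 sulfur; no ring), on an oxygen on a saturated carbon. Among the compounds with values here, the only measured step that bears on it is the exchange of the sulfur-bearing group for the oxygen-bearing one, a 1.4-fold lower number from compound 1 to compound 2 (0.13 log units; within the scatter), which lay within the scatter; no measured step carries the cyclopentyl ring. The move from compound 3 to compound 4 in this assay is therefore expected to stay near the scatter, with a somewhat higher number as the likelier outcome. Compound 4 is estimated at 80 nM, with a range from 30 nM to 250 nM. This corresponds to an expected step of a 1.5-fold higher number from compound 3 to compound 4 (0.16 log units; within the scatter).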

Compound 4, inhibition constant: 226 nM
Estimate against measurement, compound 4: 2.8-fold (0.45 log units) below; low and high end bracket the measured number.
By their numbers in this assay, from the lowest: compounds 3, 2 and 1 (each within the scatter of the next); then compound 4.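

In this assay the cyclopentyl group on the amide-type nitrogen is the only change shown at this oxygen that moves the number beyond the scatter (a 2.4-fold higher number from compound 1 to compound 4 (0.37 log units; beyond the scatter)). The steps from the sulfur-bearing groups are also beyond the scatter (a 3.2-fold higher number from compound 2 to compound 4 (0.50 log units; beyond the scatter); a 4.1-fold higher number from compound 3 to compound 4 (0.61 log units; beyond the scatter)), so compound 4 stands apart from compounds 1, 2 and 3. No measurement here explains this step.

The compounds shown leave open how an ethyl or a longer chain on that nitrogen would read. They also leave open whether a cyclopropyl or cyclohexyl ring there would give a similar number.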